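Dropping the Aromatic Ring from a Benzyloxymethyl Side Chain

The compounds below may be only part of what the source reports. "The series", "measured", "known", "first", "only" and "open" are said of these compounds alone.

The series rests on a shared dioxide core carrying an amino-linked ether chain. Compound 1 `O=[N+]([O-])c1cccc(COCNc2n[n+]([O-])c3ccccc3[n+]2[O-])c1` gives 3070 nM in a functional assay on PC-3 cells (Homo sapiens) for cytotoxicity, read by MTT assay, with a stated time of 72 h; a higher number here means a weaker inhibitor, a lower number a stronger inhibitor. Compound 2 `[O-][n+]1nc(NCOCc2ccccc2)[n+]([O-])c2ccccc21` gives 13400 nM in this assay, the highest of the two numbers measured, and its nearest neighbour is compound 1, reached by a 4.4-fold higher number from compound 1 to compound 2 (0.64 log units; beyond the scatter). Compound 3 `CCCCOCNc1n[n+]([O-])c2ccccc2[n+]1[O-]` is not yet measured. It differs from compound 2 in one place: propyl in place of phenyl on a saturated chain carbon bound to an oxygen on a saturated carbon. Among the compounds with values here, the only measured step concerns hydrogen in place of nitro on the aromatic ring, and it was modest; nothing measured describes what happens when that ring itself is traded for a chain. The expectation for compound 3 in this assay is therefore a step of a 1.1-fold higher number from compound 2 to compound 3 (0.05 log units; within the scatter), close to no change beyond the scatter, with wide uncertainty. Compound 3 is estimated at 15000 nM, with a range from 5000 nM to 45000 nM.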

Compound 3, half-maximal inhibitory concentration: 14700 nM
For compound 3 the middle estimate is 1.0-fold (0.01 log units) above the measured one; measured number inside the range.
By their numbers in this assay, from the lowest: compound 1; then compounds 2 and 3 (each within the scatter of the next).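

Trading phenyl for propyl gives a 1.1-fold higher number from compound 2 to compound 3 (0.04 log units; within the scatter) in this assay, so at this place, on a saturated chain carbon bound to an oxygen on a saturated carbon, the two groups cannot be told apart. The earlier step touched only a substituent on the aromatic ring, whereas this one shows that the ring itself can leave, with a chain of no ring entering, and the number stays within the scatter. No evidence is available that bears on why these two compounds sit so close.

Only propyl stands against phenyl here, so the compounds shown do not tell how the number responds to a longer chain such as hexyl. They also leave open whether a chain ending in an amine or a carboxylic acid would stay within the scatter of compound 2.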